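2,4-Dichlorophenyl in place of phenyl: expectation for compound 3

This account rests on a few compounds, and the source may have more. Where it says the series, first, only, none or still open, it means among the compounds named here.

Values so far in a functional assay on EKVX cells (Homo sapiens) for inhibition, read by sulforhodamine B assay, with a stated time of 48 h; on this read-out higher numbers stand for weaker inhibition of growth and lower numbers for stronger inhibition of growth
- compound 1 `O=C(Cc1csc2nc(-c3ccc(Br)cc3)cn12)N/N=C/c1ccccc1` gives 52500 nM
- compound 2 `COc1cccc(OC)c1/C=N/NC(=O)Cc1csc2nc(-c3ccc(Br)cc3)cn12` gives 57500 nM

For the measured compounds named here, compound 1 is one of only two measured members, and its number does not separate from that of compound 2, so it holds no distinct rank in this assay for now. Going by the values given here, the single measured step (a 1.1-fold higher number from compound 1 to compound 2 (0.04 log units; within the scatter)) puts 2,6-dimethoxyphenyl in place of phenyl on a carbon with a double bond to nitrogen, and it stays within the scatter.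

Compound 3 `O=C(Cc1csc2nc(-c3ccc(Br)cc3)cn12)N/N=C/c1ccc(Cl)cc1Cl` is not yet measured and carries its change at that same place, with 2,4-dichlorophenyl in place of phenyl on a carbon with a double bond to nitrogen. Among the compounds with values here, the only guide is compound 2 (57500 nM), whose substituted ring left it within the scatter of compound 1. That is one step with different substituents, so it is thin evidence and the range stays wide. In this assay no step beyond the scatter is therefore expected, and the estimated step is a 1.1-fold lower number from compound 1 to compound 3 (0.04 log units; within the scatter) for now. Compound 3 is estimated at 48000 nM (range 22000 nM to 95000 nM).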

Compound 3, concentration for total growth inhibition: > 100000 nM
Compound 3 gave a limit, no number; the forecaster's own chance of this, stated with the estimate: 15%; middle value at least 2.0-fold (0.31 log units) from the limit.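

In this assay compound 3 gives > 100000 nM, which is a limit of the assay and not a number. At this place, on a carbon with a double bond to nitrogen, the two new changes read as an at least 1.9-fold higher number from compound 1 to compound 3 (0.27 log units; that floor lies within the scatter) and an at least 1.7-fold higher number from compound 2 to compound 3 (0.24 log units; that floor lies within the scatter). The earlier pair gave two numbers within the scatter of each other, whereas 2,4-dichlorophenyl gives only a floor for each step, so the true size of the change stays unknown and substitution on this ring can no longer be taken as having no effect, though neither floor separates compound 3 from the other two compounds: the limit of > 100000 nM in this assay, at which 1 of the 3 values shown sits.

The compounds shown do not tell whether one chlorine alone on this ring would give a number within the read-out, or whether both chlorines are needed for the limit to appear. As far as these compounds go, it also stays open how a ring carrying an amine or a carboxylic acid at this place would read, and whether any change to the core of compound 1 would bring the values clearly below those of compound 1 and compound 2.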